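The source may report more compounds than this note shows. Statements on the series, on what has been measured and on what is new or still open speak of the compounds shown alone.

The shared core appears in compound 1 `O=C(O)c1ccc(Cl)cc1-c1ccc2c(c1)OC[C@H](Cc1ccc(F)cc1)[C@H]2O`, which in a functional assay with leukotriene B4 receptor (Homo sapiens) as the target (on this read-out lower numbers stand for stronger inhibition and higher numbers for weaker inhibition), gives 400 nM, a single number with no repeat. Two further compounds carry the same core with other groups on the chain carbon. Compound 2 `O=C(O)c1c(F)cccc1-c1ccc2c(c1)OC[C@H](Cc1ccccc1)[C@H]2O` has three entries in this assay, 10 nM; 40 nM; 650 nM (3 entries), which spread widely, as the several entries of compound 2 in this assay, 10 nM; 40 nM; 650 nM (3 entries) shows. Compound 3 `O=C(O)c1ccc(Cl)cc1-c1ccc2c(c1)OC[C@H](Cc1ccc(-c3ccccc3)cc1)[C@H]2O` has two entries, 26 nM; 6 nM (2 entries), as the several entries of compound 3 in this assay, 26 nM; 6 nM (2 entries) shows. Among the numbers given, compound 1 therefore stands at the high end, with the entries of compound 3 lying below it and those of compound 2 scattered on both sides.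

Compound 4 `O=C(O)c1ccc(Cl)cc1-c1ccc2c(c1)OC[C@H](Cc1ccc3ccccc3c1)[C@H]2O` differs from compound 1 by naphthalen-2-yl in place of 4-fluorophenyl on a saturated chain carbon bound to a saturated ring carbon. Among the compounds with values here, no measured pair covers exactly this change. Since compound 3, which carries a larger aromatic group at the same place, gives 26 nM; 6 nM (2 entries), the step from compound 1 to compound 4 is expected to lower the number by a 10-fold lower number from compound 1 to compound 4 (1.00 log units; beyond the scatter), clearly beyond the scatter. Compound 4 is estimated at 40 nM, with a likely range from 8 nM to 200 nM.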

Compound 4, half-maximal inhibitory concentration: 2250 nM
For compound 4 the middle estimate is 56-fold (1.75 log units) below the measured one, outside the stated range (above it).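

In this assay, a larger aromatic group on this saturated chain carbon does not by itself mean stronger inhibition: naphthalen-2-yl in place of 4-fluorophenyl gives a 5.6-fold higher number from compound 1 to compound 4 (0.75 log units; beyond the scatter), a move towards weaker inhibition. Compound 3, which also carries a larger aromatic group at this place, gives 26 nM; 6 nM (2 entries), whereas compound 4 gives 2250 nM. Among these three compounds, the result at this position therefore depends on which aromatic group is attached, not simply on whether it is larger than 4-fluorophenyl.

The compounds shown leave open how a cyclohexyl ring, a longer alkyl chain or a phenyl ring bearing an amine would behave at this place. Compound 1 and compound 4 also rest on one number each, so the size of their step has no repeat behind it.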